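Aryl versus benzyl on the triazole of the shared core

A few compounds are considered here, and "the series" means these few. Any claim that something is new, unique, unknown or untested is made for them only; others in the source may bear on it.

Measured compounds:
compound 1 `O=C1NC(O)(CCn2cc(C3=CCCCC3)nn2)C(OCc2ccccc2)=C1OCc1ccccc1`
compound 2 `CC(C)(C)c1ccc(-c2cn(CCC3(O)NC(=O)C(OCc4ccccc4)=C3OCc3ccccc3)nn2)cc1`
compound 3 `O=C1NC(O)(CCn2cc(Cc3ccccc3)nn2)C(OCc2ccccc2)=C1OCc1ccccc1`

In a functional assay on MDA-MB-231 cells (Homo sapiens) for antiproliferative activity, read by MTT assay, with a stated time of 24 h (a higher number here means a weaker inhibitor, a lower number a stronger inhibitor), compound 1 gives 13100 nM. Compound 2 reaches only the assay limit, > 100000 nM. Compound 3 likewise reaches only the assay limit, > 100000 nM. Compound 3 therefore stands at the weak end of the three, sharing the limit of > 100000 nM in this assay, at which 2 of the 3 values shown sit, with compound 2. The steps of an at least 7.6-fold higher number from compound 1 to compound 2 (0.88 log units; beyond the scatter) and an at least 7.6-fold higher number from compound 1 to compound 3 (0.88 log units; beyond the scatter) are both clear, whereas a step that the two limits leave unreadable from compound 2 to compound 3 cannot be read.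

Compound 4 `Cc1ccc(-c2cn(CCC3(O)NC(=O)C(OCc4ccccc4)=C3OCc3ccccc3)nn2)cc1` differs from compound 3 by 4-methylphenyl in place of benzyl on an aromatic carbon. Among the measured compounds shown here, the only aryl comparator, compound 2, sits at the limit, and no step between the two limit values is readable, so compound 4 is expected to stay at or near the limit, with a number no higher from compound 3 to compound 4 (the limit leaves the size open) not reliably beyond the scatter. Compound 4 is estimated at 100000 nM, between 30000 nM and 300000 nM.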

Compound 4, half-maximal inhibitory concentration: 82200 nM
Estimate against measurement, compound 4: 1.2-fold (0.09 log units) above, within the range that was stated.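

With 4-methylphenyl on this aromatic carbon, an aryl compound now gives a readable number rather than a limit in this assay, and it falls clearly behind the cyclohex-1-en-1-yl compound: a 6.3-fold higher number from compound 1 to compound 4 (0.80 log units; beyond the scatter). The steps of an at least 1.2-fold lower number from compound 3 to compound 4 (0.08 log units; that floor lies within the scatter) and an at least 1.2-fold lower number from compound 2 to compound 4 (0.08 log units; that floor lies within the scatter) show no gain that can be told from the scatter. Compound 2 and compound 3 remain limits, not numbers: the limit of > 100000 nM in this assay, at which 2 of the 4 values shown sit.

Still open, on these data alone, is whether a saturated cyclohexyl group at this position would match compound 1. Also open, as far as these compounds go, is whether an amine or a carboxylic acid on the phenyl ring would change the picture.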